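One Methyl Removed: The Expected Cytotoxicity of Compound 4

This account rests on a few compounds, and the source may have more. Where it says the series, first, only, none or still open, it means among the compounds named here.

Measured compounds in an ADME assay on Vero cells (Chlorocebus sabaeus) for cytotoxicity, read by MTT assay, with a stated time of 72 h; on this read-out higher numbers stand for lower toxicity in this test and lower numbers for higher toxicity in this test:
- compound 1 `COc1c(N2C[C@H]3CCCN(Cc4cn(CCCN5C(=O)C(=O)c6ccccc65)nn4)[C@H]3C2)c(F)cc2c(=O)c(C(=O)O)cn(C3CC3)c12`: 16 ug/mL
- compound 2 `CCO/N=C1/C(=O)N(CCCn2cc(CN3CCC[C@@H]4CN(c5c(F)cc6c(=O)c(C(=O)O)cn(C7CC7)c6c5OC)C[C@@H]43)nn2)c2ccc(C)cc21`: 4 ug/mL
- compound 3 `COc1c(N2C[C@H]3CCCN(Cc4cn(CCCN5C(=O)C(=O)c6cc(C)ccc65)nn4)[C@H]3C2)c(F)cc2c(=O)c(C(=O)O)cn(C3CC3)c12`: 32 ug/mL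

Compound 2 gives the lowest number of the three in this assay, and its distance to each of the other two lies beyond the scatter, so among these compounds it shows the highest toxicity. The difference between the core of compound 2 and the core of compound 3 is not broken down here.

Compounds 3 and 1 share a core and differ in one place: hydrogen in place of methyl on an aromatic carbon. The step in this assay is a 2.0-fold lower number from compound 3 to compound 1 (0.30 log units; within the scatter), which does not leave the usual scatter.

Compound 4 `CCO/N=C1/C(=O)N(CCCn2cc(CN3CCC[C@@H]4CN(c5c(F)cc6c(=O)c(C(=O)O)cn(C7CC7)c6c5OC)C[C@@H]43)nn2)c2ccccc21` is not yet measured. It is related to compound 2 by the same change: hydrogen in place of methyl on an aromatic carbon. The place of the change is described in the same words for both pairs, so the same change is made on a different core.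

Resting on the step from compound 3 to compound 1, a small step of the same direction is expected for compound 4, namely a 1.3-fold lower number from compound 2 to compound 4 (0.12 log units; within the scatter), with the understanding that a step of this size is indistinguishable from no change. The estimate for compound 4 in this assay is therefore 3 ug/mL, with a range from 1.5 ug/mL to 8 ug/mL.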

Compound 4, half-maximal cytotoxic concentration: 16 ug/mL
For compound 4 the middle estimate is 5.3-fold (0.73 log units) below the measured one; measured number above the stated range.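

In this assay, hydrogen in place of methyl on an aromatic carbon gives a 4.0-fold higher number from compound 2 to compound 4 (0.60 log units; beyond the scatter). Set beside the earlier pair, the change does not carry over from one core to the other as a fixed step, and the two results differ by more than repeated measurements would explain: the same change on two cores in this assay, a 2.0-fold lower number (0.30 log units; within the scatter) from compound 3 to compound 1 and a 4.0-fold higher number (0.60 log units; beyond the scatter) from compound 2 to compound 4, 8.0-fold (0.90 log units) apart, beyond the scatter of two such steps. Going by these compounds alone, this shows that, for these two pairs, a step read on one core was no reliable guide to the step on the other, but with only one pair on each core it gives no general rule for the series and does not show which difference between the cores lies behind the gap.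

The compounds shown leave open whether another group on the same aromatic carbon, such as a chlorine atom, a methoxy group or an amine, would give steps that differ between the two cores in the same way. They also leave open whether the same gap between the steps would appear in further pairs that differ only by this methyl, for example pairs carrying a longer chain elsewhere in the molecule, so the finding remains limited to the four compounds at hand.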